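A few compounds are considered here, and "the series" means these few. Any claim that something is new, unique, unknown or untested is made for them only; others in the source may bear on it.

Compound 1 `CC(C)C[C@H]1C(=O)N(CC(=O)NCCCCCC(=O)O)C[C@H](c2ccccc2Cl)c2cc(Cl)ccc21` and compound 2 `CC(C)C[C@H]1C(=O)N(CC(=O)N2CCC(CC(=O)O)CC2)C[C@H](c2ccccc2Cl)c2cc(Cl)ccc21` share one core and differ in the chain attached to it. In an ADME assay on microsomes from liver (Homo sapiens) for metabolic stability, with a stated time of 60 min (a lower number here means that less of the compound is left, a higher number that more of the compound is left), compound 1 stands as "not determined" (no result reported) and offers no number for comparison. In this assay, for the measured compounds named here, compound 2 gives 70% as the only number available, so it cannot yet be ranked against any other compound. Compound 3 `CC(C)C[C@H]1C(=O)N(CC(=O)N2CCC(C(=O)O)CC2)C[C@H](c2ccccc2Cl)c2cc(Cl)ccc21` differs from compound 2 in one place, with carboxy in place of carboxymethyl on a saturated ring carbon is the whole difference. Going by the values given here, no measured pair shows what such a change does, so the estimated step of a number 2 percentage points higher from compound 2 to compound 3 (within the scatter) is expected to stay within the usual scatter, with no firm direction. That expectation takes compound 2 at 70% as its only starting point. The middle value expected for compound 3 is 72% in an estimated range from 52% to 88% for repeated measurements.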

Compound 3, percent of the compound remaining: 53%
Beside the measured number, compound 3's estimate is 19 percentage points above it; low and high end bracket the measured number.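

In this assay the exchange of 4-(carboxymethyl)piperidin-1-yl for 4-carboxypiperidin-1-yl gives a number 17 percentage points lower from compound 2 to compound 3 (beyond the scatter). This pair therefore shows that the position on this saturated ring carbon is sensitive to a small edit: carboxymethyl and carboxy are not interchangeable there, even though the counted hydrogen-bond donors and acceptors and the net charge stay the same. Nothing among the available data explains why the number falls.

A single pair gives a direction for this one exchange only, not a trend with chain length. As far as these compounds go, how a longer chain such as carboxyethyl, or an amine or a primary amide in place of the carboxylic acid, would behave at this position remains open.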